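A few compounds are considered here, and "the series" means these few. Any claim that something is new, unique, unknown or untested is made for them only; others in the source may bear on it.

Three amides built on one shared core have been tested in an assay on isolated protein for inhibition of phosphodiesterase 4A (Sus scrofa); on this read-out lower numbers stand for stronger inhibition and higher numbers for weaker inhibition. Compound 1 `COc1ccc(C(=O)Nc2ccccn2)cc1OC1CCCC1` gives 1000 nM, compound 2 `COc1ccc(C(=O)Nc2cccnc2)cc1OC1CCCC1` gives 550 nM, and compound 3 `COc1ccc(C(=O)Nc2nccs2)cc1OC1CCCC1` gives 6500 nM, the highest number of the three and therefore the weakest inhibitor here. Going by the values given here, the steps of a 6.5-fold higher number from compound 1 to compound 3 (0.81 log units; beyond the scatter) and a 12-fold higher number from compound 2 to compound 3 (1.07 log units; beyond the scatter) both end at compound 3, and in each the 1,3-thiazol-2-yl compound is the one with the higher number. Compound 4 `COc1ccc(C(=O)Nc2c(Br)cncc2Br)cc1OC1CCCC1` carries 3,5-dibromopyridin-4-yl in place of 1,3-thiazol-2-yl on an amide-type nitrogen. Among the compounds with values here, no measured step involves a dibromopyridinyl group, but since both known steps toward pyridinyl partners gave lower numbers, a lower number is expected for compound 4 in this assay, namely an 8.1-fold lower number from compound 3 to compound 4 (0.91 log units; beyond the scatter). Compound 4 is estimated at 800 nM, with a likely range from 200 nM to 3000 nM.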

Compound 4, half-maximal inhibitory concentration: 7 nM
Estimate against measurement, compound 4: 110-fold (2.06 log units) above; the whole stated range lies above it.
By their numbers in this assay, from the lowest: compound 4; then compounds 2 and 1 (each within the scatter of the next); then compound 3.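

Going by these compounds alone, on the amide-type nitrogen, the group can change the read-out far more than the earlier compounds revealed: 3,5-dibromopyridin-4-yl gives a 930-fold lower number from compound 3 to compound 4 (2.97 log units; beyond the scatter). The same group also clearly beats both simple pyridinyl amides, with a 79-fold lower number from compound 2 to compound 4 (1.90 log units; beyond the scatter) and a 140-fold lower number from compound 1 to compound 4 (2.15 log units; beyond the scatter), making compound 4 the strongest inhibitor of the four.

No measured evidence here explains this gain. A plain pyridin-4-yl group or a 3,5-dichloropyridin-4-yl group would help separate the contribution of the two bromines from that of the ring itself.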